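This account rests on a few compounds, and the source may have more. Where it says the series, first, only, none or still open, it means among the compounds named here.

Working notes on the sulfonyl series.

Compound 1 `CCn1nc(S(=O)(=O)c2cccc3ccccc23)c2cc(N3CCN(C)CC3)ccc21` is the reference point for the step under consideration. In a functional assay on HeLa cells for antagonist activity at 5-hydroxytryptamine receptor 6 (Homo sapiens) (a higher number here means a larger maximal response, a lower number a smaller maximal response), compound 1 gives 100%. The two close relatives without the ethyl on the aromatic nitrogen sit at the same level: compound 2 `CN1CCN(c2ccc3[nH]nc(S(=O)(=O)c4ccc(Cl)cc4)c3c2)CC1` gives 100% in this assay, and compound 3 `Cc1ccc(S(=O)(=O)c2n[nH]c3ccc(N4CCN(C)CC4)cc23)cc1` gives 100% in this assay. Within the data shown here, the one measured step, no change at the digits printed from compound 2 to compound 3 (within the scatter), concerns the aryl part of the sulfonyl group and is flat. Compound 1 thus stands level with compound 2 and compound 3, and no order among the three can be read from these numbers.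

The next compound, compound 4 `CC(C)Cn1nc(S(=O)(=O)c2cccc3ccccc23)c2cc(N3CCN(C)CC3)ccc21`, differs from compound 1 only in the chain on the aromatic nitrogen: isopropyl in place of methyl on a saturated chain carbon bound to an aromatic nitrogen. Among the measured compounds shown here, no measured step touches this chain; the only step on record concerns a different place and was flat. The three measured compounds all reach the full maximal response, and nothing in the data points to the chain on the aromatic nitrogen affecting the largest response. On that basis compound 4 is expected to show no step beyond the scatter in this assay, that is a number 2 percentage points lower from compound 1 to compound 4 (within the scatter).

Estimated for compound 4 in this assay: 98%, with a range from 85% to 105%.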

Compound 4, largest response reached (reported as Imax), in percent of the reference or control that the assay uses: 100%
Estimate against measurement, compound 4: 2 percentage points below, and the stated range covers the measured number.
By their numbers in this assay, from the lowest: compounds 1, 2, 3 and 4 (each within the scatter of the next).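

In this assay, the chain on the aromatic nitrogen now has a measured step of its own, and isopropyl in place of methyl on a saturated chain carbon bound to an aromatic nitrogen gives no change at the digits printed from compound 1 to compound 4 (within the scatter), whereas the earlier step concerned only the aryl part of the sulfonyl group. Read one bond further out, the change is ethyl to isobutyl, so this place accepts a branched alkyl chain with the largest response staying level between the two compounds. No measurement on record offers an explanation for this flat step.

The compounds shown cover only these two alkyl chains at this place, so it remains open whether a chain ending in an amine, a chain ending in a carboxylic acid or a benzyl group would also stay level with compound 1 in this assay. As far as these compounds go, a much longer chain on the same nitrogen is equally open, and a flat step between two alkyl chains says nothing about how far the flat behaviour extends.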